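Methoxy on the Phenyl: What to Expect for Compound 3

A few compounds are considered here, and "the series" means these few. Any claim that something is new, unique, unknown or untested is made for them only; others in the source may bear on it.

In a functional assay on PC-12 cells (Rattus norvegicus) for cytotoxicity, read by MTT assay, with stated times of 3 h and 2 h, tested at 5 uM (on this read-out lower numbers stand for a weaker effect and higher numbers for a stronger effect at the one concentration tested), compound 1 `CCOC(=O)c1cc2ccc(OCCCCCn3cc(CNC(=O)CCCCC4CCSS4)nn3)cc2oc1=O` gives 36.4% and compound 2 `O=C(CCCCC1CCSS1)NCc1cn(CCCCCOc2ccc3cc(-c4ccccc4)c(=O)oc3c2)nn1` gives 28%, and the change a number 8.4 percentage points lower from compound 1 to compound 2 (within the scatter) leaves the two numbers within the scatter of each other, so compound 2 stands level with compound 1 rather than apart from it. Compound 3 `COc1ccc(-c2cc3ccc(OCCCCCn4cc(CNC(=O)CCCCC5CCSS5)nn4)cc3oc2=O)cc1` differs from compound 2 by methoxy in place of hydrogen on an aromatic carbon. No measured step bears directly on this change, and the only step shown stayed within the scatter, so no step beyond the scatter is expected in this assay. Compound 3 is therefore estimated at 29%, between 16% and 42%, a step of a number 1 percentage points higher from compound 2 to compound 3 (within the scatter) expected to stay within the scatter.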

Compound 3, a percentage reported as activity, at one concentration (the size of the read-out at that concentration, not a potency): 41%
Compound 3: the middle estimate sits 12 percentage points below what was measured, within the range that was stated.
By their numbers in this assay, from the lowest: compounds 2, 1 and 3 (each within the scatter of the next, the first and the last beyond it).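

Going from phenyl to 4-methoxyphenyl gives the first step beyond the scatter in this assay: a number 13 percentage points higher from compound 2 to compound 3 (beyond the scatter) is modest, but it shows that this para place on the phenyl is not indifferent to substitution. The 4-methoxyphenyl and ethoxycarbonyl groups remain level, with a number 4.6 percentage points higher from compound 1 to compound 3 (within the scatter) on that exchange. No measurement shown accounts for the step. Still open, on these data alone, is whether this step is specific to methoxy, or whether a hydroxyl, an amine or a longer alkoxy chain at the same place would give a similar result.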